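Hydroxy and carboxylic acid quinoline amides on A-375

The compounds below may be only part of what the source reports. "The series", "measured", "known", "first", "only" and "open" are said of these compounds alone.

Measured so far:
compound 1, `CCc1ccc2nc(C(=O)Nc3c(F)cc(-c4cccc(F)c4)cc3F)c(C)c(O)c2c1`: 0.68%
compound 2, `Cc1ccc2nc(C(=O)Nc3c(F)cc(-c4cccc(F)c4)cc3F)c(C)c(C(=O)O)c2c1`: 0.35%

In a functional assay on A-375 cells (Homo sapiens) for antiproliferative activity, read by MTT assay, with a stated time of 24 h, tested at 0.05 ug/mL (on this read-out lower numbers stand for a weaker effect and higher numbers for a stronger effect at the one concentration tested), compound 1 gives 0.68%. In this assay compound 2 gives 0.35%. The two values sit within the scatter of each other, so compound 2 cannot be set apart from compound 1 on these numbers; both read-outs are small, close to no effect at the concentration tested. Within the data shown here, no step between measured compounds that differ in one place is available in this pair, since compound 1 and compound 2 differ in more than one place.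

Compound 3, `CCc1ccc2nc(C(=O)Nc3c(F)cc(-c4cccc(F)c4)cc3F)c(C)c(C(=O)O)c2c1`, is not yet measured in this assay. It is reached from compound 2 by one change: methyl in place of hydrogen on a saturated chain carbon bound to an aromatic carbon. Compound 3 carries the carboxylic acid of compound 2 together with the ethyl of compound 1. Among the measured compounds shown here, with both measured values near the floor and no measured step of this kind to lean on, no step beyond the scatter is expected from compound 2 to compound 3 in this assay; the estimated step is a number 0.2 percentage points higher from compound 2 to compound 3 (within the scatter). Compound 3 is expected to give about 0.5% in this assay, with a range from 0% to 8%.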

Compound 3, a percentage reported as inhibition, at one concentration (the size of the read-out at that concentration, not a potency): 0.95%
For compound 3 the middle estimate is 0.5 percentage points below the measured one; the range from low to high includes it.
By their numbers in this assay, from the lowest: compounds 2, 1 and 3 (each within the scatter of the next).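

In this assay, among these compounds, the methyl to ethyl change, on a saturated chain carbon bound to an aromatic carbon, gives a number 0.6 percentage points higher from compound 2 to compound 3 (within the scatter) and so offers the first one-place reading at this position: with the carboxylic acid present, methyl and ethyl cannot be told apart here. The second one-place reading, carboxy in place of hydroxy on an aromatic carbon, gives a number 0.3 percentage points higher from compound 1 to compound 3 (within the scatter) and shows that, with the ethyl present, these two groups cannot be told apart either. No measurement is available that would account for either reading.

All three compounds remain close to no effect at the one concentration tested, so these readings cannot show whether either change would matter under conditions where the series has a clear effect. On these data alone, it also remains open whether a longer chain such as propyl at the saturated chain position, or an amine or methoxy group in place of the carboxy or hydroxy group, would give a read-out beyond the scatter.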